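The compounds below may be only part of what the source reports. "The series", "measured", "known", "first", "only" and "open" are said of these compounds alone.

Compound 2 `COc1ccc2c(=O)c(-c3cc(OC)c(OC)cc3OC)coc2c1` gives 2640 nM in a functional assay on A-375 cells (Homo sapiens) for antiproliferative activity, read by MTT assay, with a stated time of 24 h (on this read-out lower numbers stand for stronger inhibition and higher numbers for weaker inhibition), the higher of the two numbers measured, while compound 1 `COc1cc(OC)c(-c2coc3cc(OCC=C(C)C)ccc3c2=O)cc1OC` gives 1580 nM, within the scatter of it. Compound 3 `COc1cccc(C(=O)Oc2ccc3c(=O)c(-c4cc(OC)c(OC)cc4OC)coc3c2)c1` reaches only the limit > 10000 nM, which is a limit of this assay (the limit of > 10000 nM in this assay, at which 1 of the 3 values shown sits). Compound 4 `COc1cc(OC)c(-c2coc3cc(OCc4ccccc4C)ccc3c2=O)cc1OC` carries 2-methylphenyl in place of hydrogen on a saturated chain carbon bound to an oxygen on an aromatic ring. The step of a 1.7-fold higher number from compound 1 to compound 2 (0.22 log units; within the scatter) runs the other way over the same chain carbon and is the nearer guide; the step of an at least 3.7-fold higher number from compound 2 to compound 3 (0.57 log units; beyond the scatter) alters the oxygen itself and bears less on it. A step of a 1.3-fold lower number from compound 2 to compound 4 (0.12 log units; within the scatter) in this assay is therefore expected, with no movement beyond the scatter. The estimate for compound 4 is 2000 nM, within 800 nM to 5000 nM.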

Compound 4, half-maximal inhibitory concentration: 1360 nM
The estimate for compound 4 lay 1.5-fold (0.17 log units) above the measured number; measured number inside the range.
By their numbers in this assay, from the lowest: compounds 4, 1 and 2 (each within the scatter of the next). At a limit, above all of these: compound 3.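

In this assay, a carbon-only aromatic ring on the saturated chain carbon leaves the number within the scatter, both against hydrogen, with a 1.9-fold lower number from compound 2 to compound 4 (0.29 log units; within the scatter), and against the open chain, with a 1.2-fold lower number from compound 1 to compound 4 (0.07 log units; within the scatter). An aromatic ring in this part of the molecule therefore does not by itself separate compound 3 from the others, since 2-methylbenzyl in place of (3-methoxyphenyl)carbonyl gives an at least 7.3-fold lower number from compound 3 to compound 4 (0.86 log units; beyond the scatter). Compound 3 stands at a limit, not a number: the limit of > 10000 nM in this assay, at which 1 of the 4 values shown sits.

The compounds shown leave open what an amine or a carboxylic acid on that chain carbon would do. They also leave open whether a phenyl without its methyl would read the same.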